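Working notes on a small series and one pending analogue

The source may hold more compounds than are shown below. What is called first, only, known or untested is meant among the compounds shown, and "the series" means these compounds.

Measured so far:
- Compound 1 `COc1ccc2nc(NC(c3cn(-c4ccccc4)nc3-c3ccc(Cl)cc3)c3c(O)ccc4ccccc34)sc2c1` gives, in a functional assay on A549 cells (Homo sapiens) for antiproliferative activity, read by MTT assay, with a stated time of 48 h (on this read-out lower numbers stand for stronger inhibition and higher numbers for weaker inhibition), 34500 nM.
- Compound 2 `COc1ccc2nc(NC(c3cn(-c4ccccc4)nc3-c3ccc(F)cc3)c3c(O)ccc4ccccc34)sc2c1` gives in this assay 33600 nM.
- Compound 3 `COc1ccc(-c2nn(-c3ccccc3)cc2C(Nc2nc3ccc(OC)cc3s2)c2c(O)ccc3ccccc23)cc1` gives in this assay 28100 nM.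

All three numbers sit close together. The change from compound 3 to compound 1 is chloro in place of methoxy on an aromatic carbon, and it moved the read-out by a 1.2-fold higher number from compound 3 to compound 1 (0.09 log units; within the scatter). The change from compound 3 to compound 2 is fluoro in place of methoxy on an aromatic carbon, with a step of a 1.2-fold lower number from compound 2 to compound 3 (0.08 log units; within the scatter) read in the opposite direction; compound 1 and compound 2 differ by a 1.0-fold lower number from compound 1 to compound 2 (0.01 log units; within the scatter). None of these steps leaves the scatter, so no ordering among compound 1, compound 2 and compound 3 is claimed.

Pending is compound 4 `Oc1ccc2ccccc2c1C(Nc1nc2ccc(Cl)cc2s1)c1cn(-c2ccccc2)nc1-c1ccc(F)cc1`. It differs from compound 2 by chloro in place of methoxy on an aromatic carbon. This is the same kind of change as that from compound 3 to compound 1, not the same one: there the place was on an aromatic carbon of a six-membered aromatic ring of carbon only, para to a large group, whereas here the place is part of a fused or bridged system of two rings, meta to a fused ring and para to a fused ring. For the measured compounds named here, with only one measured example of this kind of change, and that example within the scatter, the expectation for compound 4 rests on compound 2 at 33600 nM and on the step of a 1.2-fold higher number from compound 3 to compound 1 (0.09 log units; within the scatter). The expected step from compound 2 to compound 4 in this assay is a 1.1-fold higher number from compound 2 to compound 4 (0.03 log units; within the scatter). Compound 4 is therefore estimated at 36000 nM, with a likely range from 16000 nM to 80000 nM.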

Compound 4, half-maximal inhibitory concentration: 32200 nM
Compound 4: the middle estimate sits 1.1-fold (0.05 log units) above what was measured; the range from low to high includes it.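

In this assay, the change from 6-methoxy-1,3-benzothiazol-2-yl to 6-chloro-1,3-benzothiazol-2-yl gives a 1.0-fold lower number from compound 2 to compound 4 (0.02 log units; within the scatter). Set beside the earlier case of chloro in place of methoxy, at a different place in the molecule, the two steps do not differ: the same change on two cores in this assay, a 1.2-fold higher number (0.09 log units; within the scatter) from compound 3 to compound 1 and a 1.0-fold lower number (0.02 log units; within the scatter) from compound 2 to compound 4, 1.3-fold (0.11 log units) apart, within the scatter of two such steps

This shows that, in these two pairs, the exchange leaves the read-out within the scatter on both cores, so the two results agree, but only in that neither step can be told from no change. It does not show that a real effect of this change carries from one core to another, since neither pair displays such an effect, and two pairs give no general rule for the series.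

The compounds shown leave open whether any group at these two places can move the read-out beyond the scatter, as only methoxy, chloro and fluoro appear there. An amine, a carboxylic acid or a longer alkyl chain at either place would test this, and would show whether the two places then still behave alike.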